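Hydroxy for Fluoro on the Aryl Ring of Compound 3

A few compounds are considered here, and "the series" means these few. Any claim that something is new, unique, unknown or untested is made for them only; others in the source may bear on it.

Compound 3 `CCn1nnc(-c2sc(-c3ccc(F)cc3)nc2O)n1` gives 286 nM in an assay on HEK293 cells for inhibition of transient receptor potential cation channel subfamily M member 8 (Homo sapiens), read by FLIPR, with stated times of 5 min and 3 min (on this read-out higher numbers stand for weaker inhibition and lower numbers for stronger inhibition), the lowest of the three numbers recorded. Compound 2 `CCN(C)C(=O)c1sc(-c2ccccc2)nc1O` gives 6400 nM in this assay, and compound 1 `CCn1nnc(-c2sc(-c3ccc(Cl)cc3)nc2O)n1` gives 7550 nM. Among the measured compounds shown here, the only single-place step measured, a 26-fold lower number from compound 1 to compound 3 (1.42 log units; beyond the scatter), shows that the ring carbon para to a large group is sensitive to what sits there. Compound 4 `CCn1nnc(-c2sc(-c3ccc(O)cc3)nc2O)n1` carries hydroxy in place of fluoro on an aromatic carbon. For the measured compounds named here, no measured step exchanges a halogen for a hydroxy, so the direction is uncertain, and the halogen swap between compound 1 and compound 3 shows only that this position matters. Compound 4 is therefore expected to give roughly 1500 nM, within a range from 200 nM to 10000 nM, the estimated step of a 5.2-fold higher number from compound 3 to compound 4 (0.72 log units; beyond the scatter) reflecting a probable loss.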

Compound 4, half-maximal inhibitory concentration: 11600 nM
Beside the measured number, compound 4's estimate is 7.7-fold (0.89 log units) below it, outside the stated range (above it).
By their numbers in this assay, from the lowest: compound 3; then compounds 2, 1 and 4 (each within the scatter of the next).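

Hydroxy in place of fluoro on the aromatic carbon gives a 41-fold higher number from compound 3 to compound 4 (1.61 log units; beyond the scatter) in this assay and so shows that the sensitivity of this position extends beyond a swap between halogens. Hydroxy in place of chloro gives a 1.5-fold higher number from compound 1 to compound 4 (0.19 log units; within the scatter) and leaves these two compounds within the scatter of each other, so that among the three groups compared here only fluoro gives the low number. No evidence is available to explain this result. The compounds shown leave open whether an amine, a methoxy group or a nitrile at this place would match fluoro or fall with chloro and hydroxy.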